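The source may report more compounds than this note shows. Statements on the series, on what has been measured and on what is new or still open speak of the compounds shown alone.

Measured so far:
Compound 1 `CN(C)c1ccc(C=C2C(=O)N(c3ccc(Cl)cc3)N(c3ccc(Cl)cc3)C2=O)cc1` gives > 128000 nM in a functional assay on MCF7 cells (Homo sapiens) for cytotoxicity, read by MTT assay, with a stated time of 72 h (a higher number here means a weaker inhibitor, a lower number a stronger inhibitor), a limit rather than a number.
Compound 2 `COc1ccc(C=C2C(=O)N(c3ccc(Cl)cc3)N(c3ccc(Cl)cc3)C2=O)cc1` gives > 128000 nM in this assay, again only a limit.

Compound 1 therefore stands at a limit in this assay, with no measured number of its own. For the measured compounds named here, the one change measured so far, methoxy in place of dimethylamino on an aromatic carbon, leaves a step of unreadable size, a step that the two limits leave unreadable from compound 1 to compound 2, because of the limit of > 128000 nM in this assay, at which 2 of the 2 values shown sit. So the two values merely show that neither compound 1 nor compound 2 reached a readable strength in this assay.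

Compound 3 `O=C1C(=Cc2ccco2)C(=O)N(c2ccc(Cl)cc2)N1c1ccc(Cl)cc1` differs from compound 1 at another place: furan-2-yl in place of 4-(dimethylamino)phenyl on a double-bonded chain carbon bound to a double-bonded ring carbon. Going by the values given here, no measured step touches this part of the shared core, and the only measured step gives no size to borrow. The expectation for compound 3 rests solely on the two limits, which point towards weak activity across this core. Compound 3 is thus estimated at 120000 nM, with a range of 30000 nM to 400000 nM, and very likely only a limit again. The step of an at least 1.0-fold lower number from compound 1 to compound 3 (0.02 log units; that floor lies within the scatter) is expected to stay within the scatter.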

Compound 3, half-maximal inhibitory concentration: 20300 nM
Compound 3: the middle estimate sits 5.9-fold (0.77 log units) above what was measured; measured number outside the range, below it.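

In this assay, for the compounds shown here, this is the first change to the shared core that yields a step of readable size. Furan-2-yl in place of 4-(dimethylamino)phenyl on a double-bonded chain carbon bound to a double-bonded ring carbon gives an at least 6.3-fold lower number from compound 1 to compound 3 (0.79 log units; beyond the scatter), and furan-2-yl in place of 4-methoxyphenyl at the same place gives an at least 6.3-fold lower number from compound 2 to compound 3 (0.79 log units; beyond the scatter). The group at this place therefore does bear on the strength of the compound, something the swap of dimethylamino for methoxy could not show, as that step cannot be read. Both new steps are only minimum sizes, and their true sizes stay unknown, because the two starting compounds have no number of their own: the limit of > 128000 nM in this assay, at which 2 of the 3 values shown sit.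

From the compounds shown here alone, with a single five-membered ring at this place, it remains open whether the furan-2-yl ring itself matters or whether the two substituted phenyl groups were simply poorly suited here, a question that an unsubstituted phenyl or a thiophen-2-yl group could help settle. Going by these compounds, how the number would respond to an amine or a carboxylic acid attached to the furan-2-yl ring also remains unknown.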